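The source may report more compounds than this note shows. Statements on the series, on what has been measured and on what is new or still open speak of the compounds shown alone.

Working notes on the series in an ADME assay on cells (Homo sapiens) for cytotoxicity; on this read-out higher numbers stand for lower toxicity in this test and lower numbers for higher toxicity in this test. Compound 1 `CCCc1nc(-c2ccc(OCCC(C)CCN3CCN(c4ccncc4)C3=O)cc2)no1` yields only a limit: in this assay compound 1 reads > 12500 nM, which is a limit of the test and not a number. Compound 2 `O=C1N(CCC2(CCOc3ccc(-c4ccc(Cl)cc4)cc3)CCCCC2)CCN1c1ccncc1` also reaches a limit, reading > 25000 nM in this assay. Compound 3 `CC(C)(CCCN1CCN(c2ccncc2)C1=O)COc1ccc(-c2ccc(Cl)cc2)cc1` reads > 25000 nM in this assay, again a limit. Among the compounds with values here, compound 1 thus stands at the limit of > 12500 nM in this assay, at which 1 of the 3 values shown sits, while the other two sit at the limit of > 25000 nM in this assay, at which 2 of the 3 values shown sit; no numeric step between measured compounds can be drawn. Compound 4 `CC(CCOc1ccc(-c2ccc(Cl)cc2)cc1)CCN1CCN(c2ccncc2)C1=O` is still unmeasured and differs from compound 1 by 4-chlorophenyl in place of 5-propyl-1,2,4-oxadiazol-3-yl on an aromatic carbon. Compound 3 carries the same 4-chlorophenyl group and sits at the limit of > 25000 nM in this assay, at which 2 of the 3 values shown sit, so no shift beyond the scatter is expected. In this assay the step is expected to be a step that the limit leaves unreadable from compound 1 to compound 4. For compound 4 the estimate in this assay is 25000 nM, ranging from 10000 nM to 60000 nM, most likely reported once more as a limit.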

Compound 4, half-maximal cytotoxic concentration: > 25000 nM
Compound 4 was reported as a limit; the forecaster's own chance of this, stated with the estimate: 80%; the middle value sits exactly at the limit.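

Within the data shown here, compound 1 and compound 4 both stand as limits in this assay, so no step between them can be read. The compounds shown leave open at what concentration any of them becomes cytotoxic.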